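Adding a Cyclopentylurea to an Inactive Oxadiazole Sulfonamide

The compounds below may be only part of what the source reports. "The series", "measured", "known", "first", "only" and "open" are said of these compounds alone.

Compound 1 `O=C(Nc1ccc(-c2noc(-c3cccc(NS(=O)(=O)c4ccccc4)c3)n2)c(Cl)c1)c1cccnc1` was tested in a functional assay on MDA-MB-231 cells (Homo sapiens) for antiproliferative activity, read by MTT assay, with a stated time of 72 h; on this read-out lower numbers stand for stronger inhibition and higher numbers for weaker inhibition. In this assay compound 1 gives > 10000 nM, which is a limit of the assay rather than a measured number. Compound 2 `CC(=O)Nc1ccc(S(=O)(=O)Nc2cccc(-c3nc(-c4ccc(NC(=O)c5cccnc5)cc4C(F)(F)F)no3)c2)cc1` differs from compound 1 at more than one place. In this assay compound 2 gives > 10000 nM, again a limit. Both values sit at the limit of > 10000 nM in this assay, at which 2 of the 2 values shown sit, so compound 1 stands at the weak end of what the data show, and no number separates it from compound 2. Compound 3 `O=C(Nc1ccc(S(=O)(=O)Nc2cccc(-c3nc(-c4ccc(NC(=O)c5cccnc5)cc4Cl)no3)c2)cc1)NC1CCCC1` is not yet measured. It differs from compound 1 by (cyclopentylcarbamoyl)amino in place of hydrogen on an aromatic carbon. Among the measured compounds shown here, no step between measured compounds is available to calibrate this change. Compound 2, which also sits at the limit while carrying another group, gives no sign that such an addition brings a measurable gain. The step that the limit leaves unreadable from compound 1 to compound 3 is therefore expected to be none beyond the scatter. Compound 3 is expected to give about 12000 nM, within 3000 nM to 40000 nM, most likely reported only as a limit.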

Compound 3, half-maximal inhibitory concentration: > 10000 nM
Compound 3: only a limit was reported (the forecaster's own chance of this, stated with the estimate: 70%); the middle value lies beyond the limit too.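

Compound 3, like compound 1, ends at a limit, so no step between them can be read: the limit of > 10000 nM in this assay, at which 3 of the 3 values shown sit.

The compounds shown leave open whether the (cyclopentylcarbamoyl)amino group changes the activity at all, and whether any compound on this shared core gives a measurable value.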